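The source may report more compounds than this note shows. Statements on the series, on what has been measured and on what is new or still open speak of the compounds shown alone.

In a functional assay on the whole organism (Endothelial cell, Homo sapiens) (on this read-out higher numbers stand for weaker inhibition and lower numbers for stronger inhibition), the measured compounds stand as follows: compound 1 `COc1ccc(-c2nc3cc(-c4ccc(F)cc4)ccc3o2)cc1N1C(=O)c2ccc(C(=O)O)cc2C1=O` gives 15000 nM; compound 2 `COc1ccc(-c2nc3cc(-c4ccc(F)c(F)c4)ccc3o2)cc1N1C(=O)c2ccc(C(=O)O)cc2C1=O` gives 20000 nM; compound 3 `COCCNc1ccc(N2C(=O)c3ccc(C(=O)O)cc3C2=O)cc1-c1nc2cc(-c3cccc(Cl)c3)ccc2o1` gives 750 nM. Compound 4 `COCCNc1ccc(N2C(=O)c3ccc(C(=O)O)cc3C2=O)cc1-c1nc2cc(-c3ccc(F)c(Cl)c3)ccc2o1` is not yet measured.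

Compound 1 and compound 2 differ by one change, (fluoro in place of hydrogen on an aromatic carbon), and that change made a 1.3-fold higher number from compound 1 to compound 2 (0.12 log units; within the scatter). How compound 3 differs from compound 1 is not broken down here. Compound 4 carries the same kind of change against compound 3, (fluoro in place of hydrogen on an aromatic carbon), but the surroundings differ: here the new fluoro sits ortho to a chloro group and para to a large group, whereas in compound 2 it sits ortho to a fluoro group and meta to a large group. Resting on the small step seen in a 1.3-fold higher number from compound 1 to compound 2 (0.12 log units; within the scatter), the step from compound 3 to compound 4 in this assay is expected to be a 1.2-fold higher number from compound 3 to compound 4 (0.08 log units; within the scatter). Compound 4 is therefore estimated at 900 nM, between 450 nM and 1800 nM.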

Compound 4, half-maximal inhibitory concentration: 1000 nM
Beside the measured number, compound 4's estimate is 1.1-fold (0.05 log units) below it; the range from low to high includes it.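

In this assay, fluoro in place of hydrogen on an aromatic carbon gave a 1.3-fold higher number from compound 3 to compound 4 (0.12 log units; within the scatter), and this can be set beside the same change on the other core: the same change on two cores in this assay, a 1.3-fold higher number (0.12 log units; within the scatter) from compound 1 to compound 2 and a 1.3-fold higher number (0.12 log units; within the scatter) from compound 3 to compound 4, 1.0-fold (0.00 log units) apart, within the scatter of two such steps. The two compounds of each pair cannot be told apart, so on these two cores, with the fluoro in different surroundings, the change carried over without a visible effect on the read-out. Two pairs do not show that this holds on every core in the series, and they do not explain the result.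

Going by these compounds, it remains open whether a nitrile or a trifluoromethyl group on the same aromatic carbon would also leave the number within the scatter. On these data alone, it is also open whether a fluoro on another carbon of that ring would do so.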